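The source may hold more compounds than are shown below. What is called first, only, known or untested is meant among the compounds shown, and "the series" means these compounds.

Compound 1 `C/C1=C\CC[C@]2(C)O[C@@H]3C[C@@H](C)[C@@](C)(CC1)C1=C3[C@](O)(OC1)[C@H]2O` gives 1260 nM in an assay for binding affinity to platelet-activating factor receptor (Homo sapiens); a lower number here means a stronger inhibitor, a higher number a weaker inhibitor.
Compound 2 `C/C1=C\CC[C@]2(C)O[C@H]2[C@@]2(O)OCC3=C2[C@H](O)C[C@@H](C)[C@]3(C)CC1` gives 1120 nM in this assay.

For the measured compounds named here, compound 2 has the lower of the two numbers measured so far, yet the gap to compound 1 lies within the usual scatter, so the two compounds cannot be told apart on these data. Compound 3 `C/C1=C\CC[C@@]2(C)O[C@@H]2[C@@]2(O)OCC3=C2[C@@H](O)C[C@@H](C)[C@]3(C)CC1` has not yet been measured. Compared with compound 2 the change is this: the two compounds have the same atoms and bonds and differ only in configuration as drawn: 3 of 7 stereo elements differ; a stereocentre at a saturated ring carbon is drawn S in compound 2 and R in compound 3; a stereocentre at a saturated ring carbon is drawn R in compound 2 and S in compound 3; a stereocentre at a saturated ring carbon is drawn R in compound 2 and S in compound 3. Going by the values given here, no pair of measured compounds differs only in configuration, so nothing here shows how large a step such an inversion brings, or in which direction. A change at three saturated ring carbons of the shared core could move the number either way; with no guide, the expectation is a number close to that of compound 2, within a wide range. Compound 3 is therefore estimated at 1500 nM, between 400 nM and 6000 nM, an expected step of a 1.3-fold higher number from compound 2 to compound 3 (0.13 log units; within the scatter) that rests on no direct comparison.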

Compound 3, half-maximal inhibitory concentration: 1450 nM
The estimate for compound 3 lay 1.0-fold (0.01 log units) above the measured number, within the range that was stated.
By their numbers in this assay, from the lowest: compounds 2, 1 and 3 (each within the scatter of the next).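

For the compounds shown here, this pair gives the first measured step for a change of configuration alone, and what makes the comparison clean is a single fact: the fact that compounds 2 and 3 differ only in the configuration as drawn. In this assay, inverting three saturated ring carbons of the shared core gives a 1.3-fold higher number from compound 2 to compound 3 (0.11 log units; within the scatter), so compound 2 and compound 3 cannot be told apart on these data. For this pair, then, redrawing these three stereocentres together does not produce a step that can be distinguished from ordinary repeat-to-repeat variation.

Since all three centres differ at once, the data cannot show whether each inversion alone would be just as small or whether larger single effects cancel. Also open, as far as these compounds go, is how the number would respond to a new group on the shared core, such as an amine or a carboxylic acid.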